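The compounds below may be only part of what the source reports. "The series", "measured", "known", "first", "only" and "open" are said of these compounds alone.

Compound 1 `Cn1c(-c2ccc(NC(=O)CSc3nc4ccccc4o3)cc2)nc(-c2ccccc2)c1-c1ccccc1` and compound 2 `Cn1c(-c2ccc(NC(=O)CSc3nc4ccccc4s3)cc2)nc(-c2ccccc2)c1-c1ccccc1` share one core and differ only in the ring that sits on the sulfur. In a functional assay on HT-29 cells (Homo sapiens) for cytotoxicity, read by MTT assay, with a stated time of 24 h, tested at 16 ug/mL (on this read-out higher numbers stand for a stronger effect at the one concentration tested and lower numbers for a weaker effect), compound 1 gives 56.2%, and in this assay compound 2 gives 47.2%. For the measured compounds named here, the one step so far, a number 9 percentage points lower from compound 1 to compound 2 (within the scatter), is within the scatter, so the two numbers cannot be told apart, and compound 2 stands as one of two measured compounds that look alike on this read-out.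

Compound 3 `Cn1ccnc1SCC(=O)Nc1ccc(-c2nc(-c3ccccc3)c(-c3ccccc3)n2C)cc1` is the next member. Relative to compound 2 the change is 1-methyl-1H-imidazol-2-yl in place of 1,3-benzothiazol-2-yl on a sulfur. Going by the values given here, the only measured step, a number 9 percentage points lower from compound 1 to compound 2 (within the scatter), swapped one bicyclic ring for another and stayed within the scatter. Among the compounds with values here, the present change goes further, removing the six-membered carbon ring entirely and leaving a smaller five-membered ring, a kind of change no measured step covers. Within the data shown here, with no step that shows a clear effect of the ring on the sulfur, a small drop is expected for compound 3, a number 9.2 percentage points lower from compound 2 to compound 3 (within the scatter), but one that may still lie within the scatter. For compound 3 a value of 38% is therefore expected, between 18% and 58%.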

Compound 3, a percentage reported as activity, at one concentration (the size of the read-out at that concentration, not a potency): 36.5%
Estimate against measurement, compound 3: 1.5 percentage points above; measured number inside the range.
By their numbers in this assay, from the lowest: compound 3; then compounds 2 and 1 (each within the scatter of the next).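

In this assay the ring on the sulfur now makes a difference that can be told from the scatter: the change to 1-methyl-1H-imidazol-2-yl gives a number 10.7 percentage points lower from compound 2 to compound 3 (beyond the scatter) when it replaces 1,3-benzothiazol-2-yl, and a number 19.7 percentage points lower from compound 1 to compound 3 (beyond the scatter) when it replaces 1,3-benzoxazol-2-yl. For the compounds shown here, these modest steps are the first at this position to lie beyond the scatter, and they show that the two groups carrying a six-membered aromatic ring of carbon only cannot be told apart from each other, while the smaller five-membered group, with 6 heavy atoms in place of 9, gives the lowest number of the three. Nothing measured here offers an explanation for this drop.

The change alters several things at once, the six-membered ring, the ring atoms and the methyl group, so the compounds shown do not tell which of these matters. On these data alone, it also remains open how the read-out would respond to a simple phenyl ring, to a ring carrying an amine or a carboxylic acid, or to a longer chain between the sulfur and the amide carbonyl.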